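Sulfonyl aryl swap in a pyrrole methylamine series

This account rests on a few compounds, and the source may have more. Where it says the series, first, only, none or still open, it means among the compounds named here.

Measured so far:
compound 1 `CNCc1cc(-c2ccccc2)n(S(=O)(=O)c2ccccc2)c1` — 96%
compound 2 `CNCc1cc(-c2cncnc2)n(S(=O)(=O)c2ccccc2)c1` — "not determined" (no result reported)
compound 3 `CNCc1cc(-c2cccnc2F)n(S(=O)(=O)c2ccccc2)c1` — 99%

In a functional assay on the whole organism (strain Jcl:SD) for inhibition, with Rattus norvegicus as the target, with stated times of 3 min and 3 h, at a dose of 1 mg/kg by the intravenous route (on this read-out higher numbers stand for more inhibition at the one dose given (going by the name of the read-out) and lower numbers for less inhibition), compound 3 gives 99%, the highest of the two numbers reported; compound 1 gives 96%, and compound 2 gives "not determined" (no result reported), so no single number for it. Going by the values given here, the only measured step, a number 3 percentage points higher from compound 1 to compound 3 (within the scatter), changes the group on an aromatic carbon, not the sulfonyl side.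

Compound 4 `CNCc1cc(-c2cccnc2F)n(S(=O)(=O)c2cccs2)c1` differs from compound 3 in thiophen-2-yl in place of phenyl on a sulfonyl sulfur. Among the compounds with values here, no measured step touches the sulfonyl substituent, so nothing among the measured pairs bears directly on this change. With both reported numbers near the top of the read-out, compound 4 is expected to give 95% in this assay, range 80% to 100%. The expected step of a number 4 percentage points lower from compound 3 to compound 4 (within the scatter) is thus estimated to lie within the scatter.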

Compound 4, a percentage reported as inhibition, in the whole organism at one dose (the size of the read-out at that dose, not a potency): 96%
Compound 4: middle estimate off by 1 percentage points, on the low side; the measured number falls inside the stated range.
By their numbers in this assay, from the lowest: compounds 1, 4 and 3 (each within the scatter of the next).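

In this assay, the sulfonyl sulfur, whose other neighbour is an aromatic nitrogen, now has a readable change: thiophen-2-yl in place of phenyl gives a number 3 percentage points lower from compound 3 to compound 4 (within the scatter) at the one dose given. A five-membered aromatic ring with 1 hetero atom therefore stands here without a separable change in the read-out, though this rests on a single pair with the fluoropyridine group held fixed. No evidence bears on why the two sulfonyl groups read alike.

The compounds shown leave open whether a non-aromatic group such as a butyl chain on the sulfonyl sulfur would keep this level of inhibition. The same holds for a carboxylic acid or an amine on the sulfonyl ring.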